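The source may hold more compounds than are shown below. What is called first, only, known or untested is meant among the compounds shown, and "the series" means these compounds.

Series notes. Compound 1 `CCCc1nn([C@H]2C[C@H](O)[C@@H](CO)S2)c(=O)[nH]c1=O`, compound 2 `Cc1nn([C@H]2C[C@H](O)[C@@H](CO)S2)c(=O)nc1N` and compound 3 `CCc1nn([C@H]2C[C@H](O)[C@@H](CO)S2)c(=O)nc1O` share one core and differ only in the groups carried on the aromatic ring. In a functional assay on E6SM cells (Homo sapiens) for cytotoxicity, read by microscopy (a higher number here means that more compound is tolerated, a lower number that less compound is tolerated), compound 1 reaches a limit of the assay, > 200 ug/mL. Compound 2 likewise gives a limit in this assay, > 200 ug/mL. Compound 3 also stops at a limit in this assay, > 200 ug/mL. Where compound 3 stands among the measured values is fixed only by the limit of > 200 ug/mL in this assay, at which 3 of the 3 values shown sit; no number separates it from compound 1 or compound 2, and nothing can be said of an order among the three.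

Compound 4 `Cc1nn([C@H]2C[C@H](O)[C@@H](CO)S2)c(=O)nc1O` is the next member to be measured. Relative to compound 3 the change is hydrogen in place of methyl on a saturated chain carbon bound to an aromatic carbon. Among the compounds with values here, no pair of measured compounds differs in just one place; no measured step sets a scale for this change, and the only guide is that all three values so far sit at one limit. No movement beyond the scatter is expected from compound 3 to compound 4 in this assay, the estimated step being a step that the limit leaves unreadable from compound 3 to compound 4. Compound 4 is expected to give an estimate in this assay of 250 ug/mL, with a range from 150 ug/mL to 450 ug/mL, most likely reported again as a limit.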

Compound 4, minimum cytotoxic concentration: > 200 ug/mL
Compound 4: a limit, no number; the forecaster's own chance of this, stated with the estimate: 85%; the middle value does not contradict the limit.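

Compound 4 gives > 200 ug/mL in this assay, which is a limit and not a number. No step can be read from compound 3 or compound 2 to compound 4: the limit of > 200 ug/mL in this assay, at which 4 of the 4 values shown sit. The compounds shown leave open how far the four differ in tolerated concentration, and whether any change on the shared core lowers it.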